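Thiophene pyridine diols: moving the second hydroxyl

The compounds below may be only part of what the source reports. "The series", "measured", "known", "first", "only" and "open" are said of these compounds alone.

Compound 3 `Oc1cccc(-c2cc(-c3ccsc3)cc(-c3ccccc3O)n2)c1` is one of the thiophen-3-yl members of the series; in a functional assay on HeLa cells (Homo sapiens) for cytotoxicity, read by CCK-8 assay (on this read-out higher numbers stand for weaker inhibition and lower numbers for stronger inhibition), compound 3 gives only a limit, > 50000 nM. Compound 2 `Oc1ccccc1-c1cc(-c2ccsc2)cc(-c2ccccc2O)n1` likewise gives only a limit in this assay, > 50000 nM. The step that the two limits leave unreadable from compound 2 to compound 3 is therefore not readable; both values sit on the limit named in the limit of > 50000 nM in this assay, at which 2 of the 3 values shown sit. Among the compounds with values here, compound 1 `Oc1cccc(-c2cc(-c3cccs3)cc(-c3cccc(O)c3)n2)c1`, which carries two 3-hydroxyphenyl groups and a thiophen-2-yl group, gives 1690 nM in this assay and is the only compound with a number.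

Compound 4 `Oc1cccc(-c2cc(-c3ccsc3)cc(-c3cccc(O)c3)n2)c1` arises from compound 3 by the change (3-hydroxyphenyl in place of 2-hydroxyphenyl on an aromatic carbon). Within the data shown here, no measured step reads on this change directly. Among the measured compounds shown here, compound 4 carries the same pair of 3-hydroxyphenyl groups as compound 1, which is the only measured compound with a number in this assay, and the estimate is built on that value of compound 1 rather than on the limits of compound 2 and compound 3. The step of an at least 12-fold lower number from compound 3 to compound 4 (1.09 log units; beyond the scatter) is expected to be towards stronger inhibition, with considerable uncertainty, since the starting point is a limit. Compound 4 is estimated at 4000 nM, with a range from 900 nM to 30000 nM.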

Compound 4, half-maximal inhibitory concentration: 16600 nM
For compound 4 the middle estimate is 4.2-fold (0.62 log units) below the measured one; low and high end bracket the measured number.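

With 3-hydroxyphenyl in place of 2-hydroxyphenyl next to the ring nitrogen, this assay now gives a number for a thiophen-3-yl member, with an at least 3.0-fold lower number from compound 3 to compound 4 (0.47 log units; beyond the scatter). That step is a bound and not a full size, since its starting point is a limit: the limit of > 50000 nM in this assay, at which 2 of the 4 values shown sit.

The thiophene attachment also counts on a core with two 3-hydroxyphenyl groups: thiophen-3-yl in place of thiophen-2-yl gives a 9.8-fold higher number from compound 1 to compound 4 (0.99 log units; beyond the scatter), so placing both hydroxyls this way does not by itself reach the number of compound 1.

On these data alone, the step between compound 2 and compound 3 cannot be read, so the effect of that first hydroxyl move remains unknown. Also open, as far as these compounds go, is whether an amine or a carboxylic acid in place of the hydroxyl would keep a measurable number, and whether the thiophene difference holds with other hydroxyl arrangements.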